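A few compounds are considered here, and "the series" means these few. Any claim that something is new, unique, unknown or untested is made for them only; others in the source may bear on it.

Measured compounds:
- compound 1 `Cc1cccnc1N(C(=O)N1CCC(c2ccccc2)CC1)[C@@H]1CCCNC1` — in an ADME assay on microsomes from liver (Homo sapiens) for metabolic stability (on this read-out higher numbers stand for fast clearance and lower numbers for slow clearance), compound 1 gives < 8 mL.min-1.g-1, a limit of the assay and not a number.
- compound 2 `O=C(N1CCC(c2cnn3cccnc23)CC1)N(c1ncccc1Cl)[C@@H]1CCCNC1` — in this assay compound 2 gives < 8 mL.min-1.g-1, again a limit of the assay.
- compound 3 `COc1ccc(CCC(=O)N(c2nccc3ccccc23)[C@@H]2CCCNC2)cc1` — in this assay compound 3 gives 21 mL.min-1.g-1.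

Compound 1 therefore stands at the limit of < 8 mL.min-1.g-1 in this assay, at which 2 of the 3 values shown sit, together with compound 2, while compound 3 alone gives a full number in this assay. Nothing can be said about the order of compound 1 and compound 2, since both are only limits.

The compound now at hand is compound 4 `Cn1ccc2ccnc(N(C(=O)N3CCC(c4ccccc4)CC3)[C@@H]3CCCNC3)c21`. The change from compound 1 is a group of 10 heavy atoms (8 carbon, 2 nitrogen; one five-membered aromatic ring with 1 hetero atom, one six-membered aromatic ring with 1 hetero atom) in place of a group of 7 heavy atoms (6 carbon, 1 nitrogen; one six-membered aromatic ring with 1 hetero atom), on an amide-type nitrogen. For the measured compounds named here, no measured pair in this set tracks a change of this kind, so the size of the step is unknown; a step of modest size in the direction of faster clearance is expected in this assay, but a result staying at the limit cannot be ruled out. Going by the values given here, compound 1 and compound 2 both sit at the limit, and the larger substituent here gives no measured precedent.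

The expected step is an at least 1.7-fold higher number from compound 1 to compound 4 (0.24 log units; that floor lies within the scatter), with compound 4 estimated at 14 mL.min-1.g-1, in the range 6 mL.min-1.g-1 to 35 mL.min-1.g-1.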

Compound 4, intrinsic clearance in microsomes: 11.8 mL.min-1.g-1
The estimate for compound 4 lay 1.2-fold (0.07 log units) above the measured number, within the range that was stated.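

In this assay compound 1 gives < 8 mL.min-1.g-1, which is a limit of the assay and not a number. With the larger group carrying a five-membered and a six-membered aromatic ring on the amide-type nitrogen in place of 3-methylpyridin-2-yl, the change can be read only as a floor: an at least 1.4-fold higher number from compound 1 to compound 4 (0.16 log units; that floor lies within the scatter). Compound 4 therefore gives the first full number on the core of compound 1, outside the limit otherwise held by compound 1 and compound 2: the limit of < 8 mL.min-1.g-1 in this assay, at which 2 of the 4 values shown sit.

Going by these compounds, the true size of the step remains open, since one end of it is a limit. Also open, on these data alone, is how a nitrile or an amine on the ring at this nitrogen would read, and whether the five-membered ring of compound 4 alone accounts for the change.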